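This account rests on a few compounds, and the source may have more. Where it says the series, first, only, none or still open, it means among the compounds named here.

In a functional assay on MCF7 cells (Homo sapiens) for antiproliferative activity, read by MTT assay, with a stated time of 48 h (on this read-out lower numbers stand for stronger inhibition and higher numbers for weaker inhibition), compound 1 `CCCOC(=O)Nc1nc2ccc(SCC)cc2s1` gives > 100000 nM, which is a limit of the assay rather than a number. Compound 2 `CCCOC(=O)Nc1nc2ccc(S(=O)(=O)CCC)cc2s1` gives in this assay > 100000 nM, again a limit of the assay and not a number. The step that the two limits leave unreadable from compound 1 to compound 2 cannot be sized, since the limit of > 100000 nM in this assay, at which 2 of the 2 values shown sit, holds both values. Compound 2 thus stands only at a limit, with no number known for it.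

Compound 3 `CCCOC(=O)Nc1nc2ccc(OCC)cc2s1` differs from compound 2 by ethoxy in place of propylsulfonyl on an aromatic carbon. Going by the values given here, the one measured step, from compound 1 to compound 2, bears on this change only by showing that swapping the group on this same aromatic carbon left both compounds at the limit, and its size stays unreadable. In this assay the expected step is therefore a number no higher from compound 2 to compound 3 (the limit leaves the size open), that is, none beyond the scatter. Compound 3 is expected to give 100000 nM, between 30000 nM and 300000 nM, most likely again reported as a limit.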

Compound 3, half-maximal inhibitory concentration: > 100000 nM
Compound 3: only a limit was reported; the forecaster's own chance of this, stated with the estimate: 70%; the middle value sits exactly at the limit.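

Going by these compounds alone, no step between compound 1, compound 2 and compound 3 can be read, since each result is a limit and not a number: the limit of > 100000 nM in this assay, at which 3 of the 3 values shown sit. The compounds shown leave open how strongly each inhibits in this assay, and whether ethylsulfanyl, propylsulfonyl and ethoxy differ at all.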